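The compounds below may be only part of what the source reports. "The series", "measured", "known", "first", "only" and "open" are said of these compounds alone.

Working notes on the series. Compound 2 `CC(C)(C)Cc1c(-c2ccc(Cl)cc2)sc(N)c1C(=O)c1ccc(Cl)cc1` gives 1% in an assay on CHO cells for displacement of a labelled ligand from adenosine receptor A1 (Homo sapiens), read by scintillation counting, tested at 10 uM (a higher number here means more inhibition at the concentration tested (going by the name of the read-out), a lower number less inhibition), and stands level with its nearest neighbour compound 1 `CC(C)(C)Cc1c(-c2cccc(F)c2F)sc(N)c1C(=O)c1ccc(Cl)cc1`, which gives 1% in this assay. The step of no change at the digits printed from compound 1 to compound 2 (within the scatter) thus left the read-out flat, with a 4-chlorophenyl in place of a 2,3-difluorophenyl on an aromatic carbon making no difference within the scatter.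

The next compound, compound 3 `CC(C)c1ccc(-c2sc(N)c(C(=O)c3ccc(Cl)cc3)c2CC(C)(C)C)cc1`, differs from compound 2 by isopropyl in place of chloro on an aromatic carbon. Within the data shown here, the only measured step that bears on this change is no change at the digits printed from compound 1 to compound 2 (within the scatter), which altered the same six-membered aromatic ring of carbon only and produced nothing beyond the scatter. Among the measured compounds shown here, nothing measured so far shows a move in this assay at all. The expected step is therefore a number 1 percentage points higher from compound 2 to compound 3 (within the scatter), no shift beyond the scatter in either direction. Compound 3 is accordingly estimated at 2%, within a range from -7% to 12%.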

Compound 3, a percentage reported as inhibition, at one concentration (the size of the read-out at that concentration, not a potency): 1%
Compound 3: middle estimate off by 1 percentage points, on the high side; the measured number falls inside the stated range.
By their numbers in this assay, from the lowest: compounds 1, 2 and 3 (each within the scatter of the next).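

The flat read-out at this place now extends beyond halogen-bearing rings: with isopropyl, an all-carbon group, in place of chloro on the aromatic carbon para to a large group, this assay shows no change at the digits printed from compound 2 to compound 3 (within the scatter). The wider exchange, 4-isopropylphenyl in place of 2,3-difluorophenyl, likewise gives no change at the digits printed from compound 1 to compound 3 (within the scatter), so neither halogen nor this alkyl group separates the three compounds. No measurement offered here accounts for this flatness.

The compounds shown leave open whether any group on this ring can lift the read-out at all, since all three share the same core and sit level with one another. An amine or a carboxylic acid at this place, or a different group in place of the 4-chlorobenzoyl carbonyl unit, remains the untested question for this series.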